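Chain Length and Unsaturation in a Thioglycoside Amide Series

The source may report more compounds than this note shows. Statements on the series, on what has been measured and on what is new or still open speak of the compounds shown alone.

Measured in a functional assay on HeLa cells (Homo sapiens) for cytotoxicity, read by MTT assay, with a stated time of 24 h; on this read-out lower numbers stand for stronger inhibition and higher numbers for weaker inhibition:
Compound 1 `CCCCCCCCCCCCCCCCCC(=O)Nc1nnc(S[C@@H]2O[C@H](CO)[C@H](O)[C@H](O)[C@H]2O)s1`: 11200 nM
Compound 2 `CCCCCCCCCCCCCCCC(=O)Nc1nnc(S[C@@H]2O[C@H](COC(C)=O)[C@H](OC(C)=O)[C@H](OC(C)=O)[C@H]2OC(C)=O)s1`: 58300 nM
Compound 3 `C=CCCCCCCCCC(=O)Nc1nnc(S[C@@H]2O[C@H](CO)[C@H](O)[C@H](O)[C@H]2O)s1`: 58300 nM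

Compound 1 gives the lowest number of the three; compound 2 and compound 3 each stand a step above it that is beyond the scatter, as a 5.2-fold higher number from compound 1 to compound 3 (0.72 log units; beyond the scatter) shows for the latter. Compound 4 `CCCCCCCC/C=C\CCCCCCCCCCCC(=O)Nc1nnc(S[C@@H]2O[C@H](CO)[C@H](O)[C@H](O)[C@H]2O)s1` differs from compound 1 by dec-1-en-1-yl in place of hexyl on a saturated chain carbon, ten or more bonds along the chain from a carbonyl carbon. For the measured compounds named here, the only measured step touching the chain, a 5.2-fold higher number from compound 1 to compound 3 (0.72 log units; beyond the scatter), came from shortening and adding a double bond; here the chain lengthens while a double bond enters, so no measured step directly matches. A change within the scatter, or a modest weakening, is expected. Compound 4 is estimated at 14000 nM, between 5000 nM and 40000 nM, meaning an expected 1.3-fold higher number from compound 1 to compound 4 (0.10 log units; within the scatter).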

Compound 4, half-maximal inhibitory concentration: 13500 nM
Estimate against measurement, compound 4: 1.0-fold (0.02 log units) above; the measured number falls inside the stated range.
By their numbers in this assay, from the lowest: compounds 1 and 4 (each within the scatter of the next); then compounds 2 and 3 (each within the scatter of the next).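

In this assay, this far along the chain, dec-1-en-1-yl in place of hexyl leaves the read-out within the scatter (a 1.2-fold higher number from compound 1 to compound 4 (0.08 log units; within the scatter)). A chain change at this site therefore need not cost activity, unlike vinyl in place of nonyl, eight bonds along the chain from a carbonyl carbon (a 5.2-fold higher number from compound 1 to compound 3 (0.72 log units; beyond the scatter)). No supporting evidence is available to explain this outcome. Going by these compounds, it remains open how the added length and the double bond each count on their own, and how a chain ending in an amine or a carboxylic acid would read.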